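Mirror image of compound 1: the inverted core

The source may hold more compounds than are shown below. What is called first, only, known or untested is meant among the compounds shown, and "the series" means these compounds.

Measured compounds:
compound 1 `CN1C[C@H]2CCCC[C@@]2(Cc2ccc(Cl)c(Cl)c2)C1`, 479 nM
compound 2 `Clc1ccc(C[C@@]23CCCC[C@@H]2CNC3)cc1Cl`, 158 nM
compound 3 `CN1C[C@@H]2CCCC[C@]2(c2ccc(Cl)cc2Cl)C1`, 1290 nM

All three were tested in an assay on CHO-K1 cells for inhibition of sodium-dependent dopamine transporter (Homo sapiens); on this read-out lower numbers stand for stronger inhibition and higher numbers for weaker inhibition. Compound 1 stands second highest of the three numbers there: its nearest neighbour is compound 3 with 1290 nM, and the furthest is compound 2 with 158 nM. Among the measured compounds shown here, the only step between compounds differing in one place is a 3.0-fold lower number from compound 1 to compound 2 (0.48 log units; beyond the scatter), which replaces the methyl on the ring amine with hydrogen.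

Compound 4 `CN1C[C@@H]2CCCC[C@]2(Cc2ccc(Cl)c(Cl)c2)C1` is the mirror image of compound 1: the two compounds have the same atoms and bonds and differ only in configuration as drawn: 2 of 2 stereo elements differ (all stereocentres are inverted: mirror images); a stereocentre at a saturated ring carbon is drawn S in compound 1 and R in compound 4; a stereocentre at a saturated ring carbon is drawn S in compound 1 and R in compound 4. For the measured compounds named here, no measured step bears on this change; the one step on record concerns the amine substituent, and compound 3 differs from compound 1 in more than configuration, so only its value can be noted beside that of compound 1. With no guide to direction, no step beyond the scatter is expected in this assay, though mirror images may well differ, so the range is wide. Compound 4 is expected to give 550 nM, between 100 nM and 3000 nM, a step of a 1.1-fold higher number from compound 1 to compound 4 (0.06 log units; within the scatter).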

Compound 4, half-maximal inhibitory concentration: 490 nM
Beside the measured number, compound 4's estimate is 1.1-fold (0.05 log units) above it; low and high end bracket the measured number.
By their numbers in this assay, from the lowest: compound 2; then compounds 1 and 4 (each within the scatter of the next); then compound 3.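

In this assay, inverting both stereocentres of the shared core gives a 1.0-fold higher number from compound 1 to compound 4 (0.01 log units; within the scatter). Among the compounds shown here, for this pair, then, the handedness of the core, which the earlier compounds did not isolate, does not separate the two values, whereas replacing the methyl on the ring amine with hydrogen gives a 3.0-fold lower number from compound 1 to compound 2 (0.48 log units; beyond the scatter). The comparison rests on a single kind of change: the fact that compounds 1 and 4 differ only in the configuration as drawn

The compounds shown leave open whether the same inversion would leave the number within the scatter for compound 2, which carries hydrogen on the ring amine, or for compound 3, which has a different aryl arrangement. They also leave open how an ethyl group or a longer chain on the ring amine would behave in either mirror-image series.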